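A few compounds are considered here, and "the series" means these few. Any claim that something is new, unique, unknown or untested is made for them only; others in the source may bear on it.

Going by the values given here, in a functional assay on PC-3 cells (Homo sapiens) for inhibition, read by sulforhodamine B assay, with a stated time of 48 h, tested at 50 uM (on this read-out higher numbers stand for more inhibition of growth at the one concentration tested and lower numbers for less inhibition of growth), compound 1 (`COc1cc(/C=C/C(=O)/C=C/c2cccc3ccccc23)ccc1OCc1cn(CCCOc2cc(=O)oc3ccccc23)nn1`) gives 8% as the only number so far. Compound 2 (`COc1ccc(/C=C/C(=O)/C=C/c2ccc(OCc3cn(CCCCOc4cc(=O)oc5ccccc45)nn3)c(OC)c2)cc1OC`) is recorded as "not active" (no number reported) without a number, so compound 1 has no numeric neighbour to be ranked against. Compound 3 (`COc1ccccc1/C=C/C(=O)/C=C/c1ccc(OCc2cn(CCCOc3cc(=O)oc4ccccc34)nn2)c(OC)c1`) has not yet been measured. Its change from compound 1 reads 2-methoxyphenyl in place of naphthalen-1-yl on a double-bonded chain carbon bound to a double-bonded chain carbon and the rest of the structure is shared, with the swap on a double-bonded chain carbon bound to a double-bonded chain carbon. Among the compounds with values here, no measured step gives a size for this swap. Within the data shown here, with compound 1 at 8% and compound 2 at "not active" (no number reported) in this assay as the only guides, no change beyond the scatter is expected in either direction. The estimated a number 2 percentage points higher from compound 1 to compound 3 (within the scatter) is therefore small. For compound 3 the expected value is 10% with an estimated range of 2% to 25% in this read-out.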

Compound 3, percent growth inhibition at one concentration: "not active" (no number reported)
No number was reported for compound 3; there is nothing to compare the estimate with.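

Going by these compounds alone, compound 3 stands without a number in this assay and so no step from compound 1 to compound 3 can be read. Going by these compounds, the size of the effect of 2-methoxyphenyl in place of naphthalen-1-yl on growth inhibition stays open. No supporting data bear on this result.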